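The source may report more compounds than this note shows. Statements on the series, on what has been measured and on what is new or still open speak of the compounds shown alone.

Working notes on the series. In a functional assay on MGC-803 cells (Homo sapiens) for cytotoxicity, read by MTT assay, with a stated time of 72 h (on this read-out higher numbers stand for weaker inhibition and lower numbers for stronger inhibition), compound 1 (`COc1cc(C=C2C(=O)N(c3ccc(Cl)cc3)N(c3ccc(Cl)cc3)C2=O)ccc1O`) gives 21800 nM and compound 2 (`O=C1C(=Cc2cccc(Cl)c2)C(=O)N(c2ccc(Cl)cc2)N1c1ccc(Cl)cc1`) gives 14400 nM within the scatter of each other, so compound 2 cannot be placed apart from compound 1 on these numbers. Compound 3 (`COc1cccc(C=C2C(=O)N(c3ccc(Cl)cc3)N(c3ccc(Cl)cc3)C2=O)c1OC`) is not yet measured. It differs from compound 2 by 2,3-dimethoxyphenyl in place of 3-chlorophenyl on a double-bonded chain carbon bound to a double-bonded ring carbon. Among the compounds with values here, the one measured step at this place (a 1.5-fold lower number from compound 1 to compound 2 (0.18 log units; within the scatter)) exchanges 4-hydroxy-3-methoxyphenyl for 3-chlorophenyl and lies within the scatter. Within the data shown here, with only that step to go on, no change beyond the scatter is expected in this assay (estimated: a 1.1-fold higher number from compound 2 to compound 3 (0.05 log units; within the scatter)). For compound 3 the estimated value is 16000 nM (expected range 7000 nM to 40000 nM).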

Compound 3, half-maximal inhibitory concentration: 29600 nM
The estimate for compound 3 lay 1.9-fold (0.27 log units) below the measured number; the measured number falls inside the stated range.
By their numbers in this assay, from the lowest: compounds 2, 1 and 3 (each within the scatter of the next, the first and the last beyond it).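

In this assay, the place on a double-bonded chain carbon bound to a double-bonded ring carbon now gives its first step beyond the scatter: 2,3-dimethoxyphenyl in place of 3-chlorophenyl gives a 2.1-fold higher number from compound 2 to compound 3 (0.31 log units; beyond the scatter), a modest change. 2,3-dimethoxyphenyl in place of 4-hydroxy-3-methoxyphenyl gives a 1.4-fold higher number from compound 1 to compound 3 (0.13 log units; within the scatter), which stays within the scatter, so these two oxygen-bearing phenyl groups cannot be told apart on these numbers. No supporting data bear on why the 3-chlorophenyl and 2,3-dimethoxyphenyl compounds differ.

Within the data shown here, with only three substituted phenyl groups at this place, it remains open whether the chlorine or the two methoxy groups set the difference. From the compounds shown here alone, it is also open whether an unsubstituted phenyl, or a phenyl carrying an amine or a carboxylic acid, would move the number further in either direction.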